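The source may report more compounds than this note shows. Statements on the series, on what has been measured and on what is new or still open speak of the compounds shown alone.

Within the data shown here, the three compounds measured so far share one core and differ only in the group on the amine nitrogen. Compound 1 `O=C1C=C(NC2CCCCC2)C(=O)c2c1nc1n2[C@H]2OC[C@@H](O)[C@H]2OC1` carries a cyclohexylamino group, compound 2 `O=C1C(N2CCC2)=CC(=O)c2c1nc1n2[C@H]2OC[C@@H](O)[C@H]2OC1` an azetidin-1-yl group, and compound 3 `O=C1C(NC2CC2)=CC(=O)c2c1nc1n2[C@H]2OC[C@@H](O)[C@H]2OC1` a cyclopropylamino group. In a functional assay on MCF7 cells (Homo sapiens) for inhibition, read by sulforhodamine B assay (on this read-out higher numbers stand for weaker inhibition and lower numbers for stronger inhibition), compound 1 gives > 8000 nM, which is a limit of the assay rather than a number. Compound 2 gives > 16000 nM, also a limit. Compound 3 gives > 16000 nM, again a limit. Compound 1 thus stands at the limit of > 8000 nM in this assay, at which 1 of the 3 values shown sits, while the other two stand at the limit of > 16000 nM in this assay, at which 2 of the 3 values shown sit. Among the measured compounds shown here, the one single change among the measured compounds, a step that the two limits leave unreadable from compound 2 to compound 3, brings cyclopropylamino in place of azetidin-1-yl, and with both ends at a limit its size cannot be read.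

Compound 4 `O=C1C=C(Nc2ccc(I)cc2)C(=O)c2c1nc1n2[C@H]2OC[C@@H](O)[C@H]2OC1` differs from compound 1 by 4-iodophenyl in place of cyclohexyl on an amine nitrogen. For the measured compounds named here, none of the measured steps exchanges a saturated ring for an aromatic one, so no measured step bears on this change, and all three measured values are limits. The step that the limit leaves unreadable from compound 1 to compound 4 is therefore expected to be none beyond the scatter, with weak inhibition persisting. Compound 4 is estimated at 10000 nM, somewhere between 2500 nM and 40000 nM, and may well be reported only as a limit once more.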

Compound 4, half-maximal inhibitory concentration: 2230 nM
The estimate for compound 4 lay 4.5-fold (0.65 log units) above the measured number; measured number outside the range, below it.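

In this assay, among these compounds, compound 4 is the first compound here whose value is a number and not a limit, so the group on this amine nitrogen can now be seen to matter. Putting 4-iodophenyl in place of cyclohexyl gives an at least 3.5-fold lower number from compound 1 to compound 4 (0.55 log units; beyond the scatter) and so stronger inhibition, a change beyond the usual scatter. That step gives only the smallest size the change can have, and the true gap may be larger, because the starting value of compound 1 is not a number: the limit of > 8000 nM in this assay, at which 1 of the 4 values shown sits. No measured property of these compounds accounts for the gain.

Among the compounds shown here, the single change swaps a saturated ring for an aromatic one and also brings in iodine, so it remains open which of the two goes with the stronger inhibition, and a plain phenyl group on the same nitrogen would separate them. A benzyl group there would further show whether the aromatic ring must sit directly on the amine nitrogen for this level of inhibition to hold.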